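The source may report more compounds than this note shows. Statements on the series, on what has been measured and on what is new or still open speak of the compounds shown alone.

In a functional assay on Bel7402/5-FU cells (Homo sapiens) for antiproliferative activity, read by MTT assay, with a stated time of 72 h (on this read-out higher numbers stand for weaker inhibition and lower numbers for stronger inhibition), compound 1 `C=C1C(=O)O[C@H]2[C@H]1CC/C(COC(=O)Cn1cc(F)c(=O)n(Cc3ccc(Cl)cc3)c1=O)=C\CC[C@@]1(C)O[C@@H]21` gives 2420 nM, compound 2 `C=C1C(=O)O[C@H]2[C@H]1CC/C(COC(=O)Cn1cc(F)c(=O)n(Cc3ccc(Br)cc3)c1=O)=C\CC[C@@]1(C)O[C@@H]21` gives 3240 nM and compound 3 `C=C1C(=O)O[C@H]2[C@H]1CC/C(COC(=O)Cn1cc(F)c(=O)n(Cc3cccc(F)c3)c1=O)=C\CC[C@@]1(C)O[C@@H]21` gives 3700 nM. These values lie within the usual scatter of one another, so compound 3 cannot be separated from the other two. Compound 4 `C=C1C(=O)O[C@H]2[C@H]1CC/C(COC(=O)Cn1cc(F)c(=O)n(Cc3cc(F)ccc3F)c1=O)=C\CC[C@@]1(C)O[C@@H]21` turns the 3-fluorobenzyl of compound 3 into 2,5-difluorobenzyl: fluoro in place of hydrogen on an aromatic carbon. The new fluoro sits on an aromatic carbon, ortho to a large group and para to a fluoro group. Going by the values given here, no measured step adds a fluoro in place of hydrogen. The closest steps swap groups on this aromatic ring: a 1.3-fold higher number from compound 1 to compound 2 (0.13 log units; within the scatter), a 1.5-fold higher number from compound 1 to compound 3 (0.18 log units; within the scatter) and a 1.1-fold higher number from compound 2 to compound 3 (0.06 log units; within the scatter), all small. No change beyond the scatter is therefore expected in this assay. The expected step is a 1.2-fold lower number from compound 3 to compound 4 (0.06 log units; within the scatter). For compound 4 the estimated value is 3200 nM, with an expected range of 1600 nM to 6400 nM.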

Compound 4, half-maximal inhibitory concentration: 4610 nM
Compound 4: middle estimate off by 1.4-fold (0.16 log units), on the low side, and the stated range covers the measured number.
By their numbers in this assay, from the lowest: compounds 1, 2, 3 and 4 (each within the scatter of the next).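

Going by these compounds alone, putting a fluoro on the aromatic carbon ortho to a large group and para to a fluoro group gives a 1.2-fold higher number from compound 3 to compound 4 (0.10 log units; within the scatter) in this assay and is the first hydrogen-to-fluoro change seen at this ring. Against the two para-halogenated benzyl compounds, 2,5-difluorobenzyl gives a 1.4-fold higher number from compound 2 to compound 4 (0.15 log units; within the scatter) and a 1.9-fold higher number from compound 1 to compound 4 (0.28 log units; within the scatter) as well, so all four compounds remain close. Nothing available here gives a reason for these small steps. Still open, from the compounds shown here alone, is whether an amine or a carboxylic acid on this ring, or a longer chain linking it to the ring nitrogen, would shift the number beyond the scatter.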